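Nitro for Bromo on a Shared Urea Scaffold

This account rests on a few compounds, and the source may have more. Where it says the series, first, only, none or still open, it means among the compounds named here.

Of the compounds shown here, three have been measured in a physicochemical assay, with a stated time of 6 min (on this read-out higher numbers stand for weaker inhibition and lower numbers for stronger inhibition), and a fourth awaits. Compound 1 `COc1ccc(NC(=O)Nc2nc(-c3cc4cc([N+](=O)[O-])ccc4o3)cs2)cc1` gives 121000 nM in this assay. Compound 2 `COc1ccc(NC(=O)Nc2nc(-c3cc4cc(Br)ccc4o3)cs2)cc1` reaches only the limit of this assay, > 200000 nM. Compound 3 `O=C(Nc1ccc(F)cc1)Nc1nc(-c2cc3cc(Br)ccc3o2)cs1` likewise stops at a limit, > 200000 nM. Compound 1 and compound 2 differ by one change, (nitro in place of bromo on an aromatic carbon), which produced an at least 1.6-fold lower number from compound 2 to compound 1 (0.21 log units; that floor lies within the scatter). Compound 2 and compound 3 differ in their cores by fluoro in place of methoxy on an aromatic carbon, a step that the two limits leave unreadable from compound 2 to compound 3.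

Compound 4 `O=C(Nc1ccc(F)cc1)Nc1nc(-c2cc3cc([N+](=O)[O-])ccc3o2)cs1` stands to compound 3 as compound 1 stands to compound 2: the change is nitro in place of bromo on an aromatic carbon, the same change in the same place as before. The earlier step is expected to repeat, so an at least 1.3-fold lower number from compound 3 to compound 4 (0.12 log units; that floor lies within the scatter) is estimated from compound 3, resting on an at least 1.6-fold lower number from compound 2 to compound 1 (0.21 log units; that floor lies within the scatter) and on (the limit of > 200000 nM in this assay, at which 2 of the 3 values shown sit). Since the start for compound 3 is itself a limit, the estimate for compound 4 is 150000 nM, with a range from 60000 nM to 400000 nM, and a real chance that the assay again reports only a limit.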

Compound 4, half-maximal inhibitory concentration: 123000 nM
Estimate against measurement, compound 4: 1.2-fold (0.09 log units) above, within the range that was stated.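

On the core carrying fluoro, nitro in place of bromo gives an at least 1.6-fold lower number from compound 3 to compound 4 (0.21 log units; that floor lies within the scatter), and on the core carrying methoxy it gives an at least 1.6-fold lower number from compound 2 to compound 1 (0.21 log units; that floor lies within the scatter), so the two cores read alike, though only as floors. Between the two nitro compounds, fluoro in place of methoxy gives a 1.0-fold higher number from compound 1 to compound 4 (0.01 log units; within the scatter), while the same change between the two bromo compounds cannot be read. This does not show that the nitro step carries from one core to another with a known size, or even that it clears the scatter, because each bromo compound stops at a limit: the limit of > 200000 nM in this assay, at which 2 of the 4 values shown sit.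

The compounds shown leave open whether an amine or a carboxylic acid in place of bromo would give a readable number on these cores. They also leave open whether the nitro step would read the same with a chlorine or a longer chain in place of fluoro or methoxy.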